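1H-Indol-6-yl in Place of 1H-Imidazol-1-yl: An Expectation

The source may hold more compounds than are shown below. What is called first, only, known or untested is meant among the compounds shown, and "the series" means these compounds.

Compound 1 `CC(C(=O)NCc1ccc(C(F)(F)F)nc1-c1cccc(Cl)c1)c1ccc(NS(C)(=O)=O)c(F)c1` gives 0.5 nM in an assay on CHO cells for antagonist activity at transient receptor potential cation channel subfamily V member 1 (Homo sapiens), read by FLIPR; on this read-out lower numbers stand for stronger inhibition and higher numbers for weaker inhibition.
Compound 2 `CC(C(=O)NCc1ccc(C(F)(F)F)nc1-c1ccco1)c1ccc(NS(C)(=O)=O)c(F)c1` gives 5.8 nM in this assay.
Compound 3 `CC(C(=O)NCc1ccc(C(F)(F)F)nc1-n1ccnc1)c1ccc(NS(C)(=O)=O)c(F)c1` gives 36.1 nM in this assay.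

Compound 3 stands highest of the three, with compound 2 nearest and compound 1 furthest. Compound 4 `CC(C(=O)NCc1ccc(C(F)(F)F)nc1-c1ccc2cc[nH]c2c1)c1ccc(NS(C)(=O)=O)c(F)c1` differs from compound 3 in one place: 1H-indol-6-yl in place of 1H-imidazol-1-yl on an aromatic carbon. Among the compounds with values here, the steps that bear on this change are a 72-fold higher number from compound 1 to compound 3 (1.86 log units; beyond the scatter) and a 6.2-fold higher number from compound 2 to compound 3 (0.79 log units; beyond the scatter); both replacements of a carbon-linked aromatic ring by 1H-imidazol-1-yl raised the number, the 3-chlorophenyl case most of all. Compound 4 returns a carbon-linked aromatic system containing a six-membered aromatic ring of carbon only, as in compound 1, so a large drop is expected: an 18-fold lower number from compound 3 to compound 4 (1.26 log units; beyond the scatter). Compound 4 is estimated at 2 nM, within 0.5 nM to 8 nM.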

Compound 4, inhibition constant: 20.3 nM
Compound 4: the middle estimate sits 10-fold (1.01 log units) below what was measured, and the stated range ends below it.
By their numbers in this assay, from the lowest: compound 1; then compound 2; then compounds 4 and 3 (each within the scatter of the next).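

In this assay, a carbon-linked aromatic system with a six-membered aromatic ring of carbon only does not by itself restore the low number at this place, as 1H-indol-6-yl shows against 1H-imidazol-1-yl (a 1.8-fold lower number from compound 3 to compound 4 (0.25 log units; within the scatter)) and against 3-chlorophenyl (a 41-fold higher number from compound 1 to compound 4 (1.61 log units; beyond the scatter)). Furan-2-yl, which lacks such a ring, gives the lower number (a 3.5-fold higher number from compound 2 to compound 4 (0.54 log units; beyond the scatter)). Nothing measured here explains this.

Going by these compounds, it remains open whether the chlorine of 3-chlorophenyl matters, which plain phenyl or 3-methoxyphenyl would test.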